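Replacing the pyridyl sulfone end group on the shared core

A few compounds are considered here, and "the series" means these few. Any claim that something is new, unique, unknown or untested is made for them only; others in the source may bear on it.

Of the compounds shown here, three have been measured in a functional assay on CHO-K1 cells with Glucose-dependent insulinotropic receptor (Homo sapiens) as the target, read by a luciferase reporter, with a stated time of 5 h; a lower number here means a smaller maximal response, a higher number a larger maximal response. Compound 1 `CC(C)(C)OC(=O)N1CCC(Oc2cccc3c2CCN3c2ccc(S(C)(=O)=O)cc2)CC1` gives 92%, compound 2 `CC(C)SC(=O)N1CCC(Oc2ncnc3c2CCN3c2ccc(S(C)(=O)=O)cc2F)CC1` gives 138%, and compound 3 `CC(C)OC(=O)N1CCC(Oc2ncnc3c2CCN3c2ccc(S(C)(=O)=O)cn2)CC1` gives 111%. Among these three numbers compound 3 stands second highest: its nearest neighbour is compound 1, which lies lower by a gap beyond the usual scatter, and the furthest is compound 2, which lies higher by a wider gap, again beyond the scatter. None of these pairs differs in just one place, so no single step can be read from them.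

Compound 4 `CC(C)OC(=O)N1CCC(Oc2ncnc3c2CCN3c2ccc([S@@+](C)[O-])c(F)c2)CC1` has not yet been measured. It differs from compound 3 in one place only: a group of 10 heavy atoms (7 carbon, 1 oxygen, 1 fluorine, 1 sulfur; one six-membered aromatic ring of carbon only) in place of a group of 10 heavy atoms (6 carbon, 1 nitrogen, 2 oxygen, 1 sulfur; one six-membered aromatic ring with 1 hetero atom), on a nitrogen on an aromatic ring in a ring. The 5-(methylsulfonyl)pyridin-2-yl group leaves and a group of the same size but with a carbon-only aromatic ring, a fluorine and a sulfur bearing one oxygen enters, on the nitrogen of the five-membered ring of the fused system.

For the measured compounds named here, because compound 2, which also carries a fluorine on a carbon-only aromatic ring, reaches 138%, a modest rise is expected, but with no direct step to lean on the expected step of a number 7 percentage points higher from compound 3 to compound 4 (within the scatter) is small and may fall within the scatter. In this assay compound 4 is therefore estimated at 118%, with a range from 88% to 148%.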

Compound 4, largest response reached (reported as percent of maximum), in percent of the reference or control that the assay uses: 155%
The estimate for compound 4 lay 37 percentage points below the measured number; the whole stated range lies below it.
By their numbers in this assay, from the lowest: compound 1; then compound 3; then compound 2; then compound 4.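

For the compounds shown here, this is the first step that can be read in one place, and it shows that the group on the nitrogen of the five-membered ring strongly affects the maximal response: in this assay, the exchange gives a number 44 percentage points higher from compound 3 to compound 4 (beyond the scatter). The change is not a single edit, however, since the ring nitrogen of the pyridine is replaced by carbon, a fluorine enters, the sulfur carries one oxygen instead of two, and a defined stereocentre appears, so this one step cannot assign the rise to any of these features. Nothing available here accounts for the size of the rise.

From the compounds shown here alone, it remains open whether the fluorine, the carbon-only aromatic ring or the sulfur with one oxygen drives the higher response, and what the other arrangement at the new stereocentre would give. Going by these compounds, it is also open whether sulfur is required at all, a question that a nitrile or a primary amide on the same carbon-only aromatic ring could address.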